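The source may report more compounds than this note shows. Statements on the series, on what has been measured and on what is new or still open speak of the compounds shown alone.

Measured so far:
compound 1 `O=C(/C=C/C1=Cc2ccccc2OC1)c1ccccc1Br` — 56.6%
compound 2 `O=C(/C=C/C1=Cc2ccccc2OC1)c1cccc(Br)c1` — 51.7%

In a functional assay on the whole organism for inhibition, with Mus musculus as the target, with a stated time of 1 h, at a dose of 30 mg/kg by the intraperitoneal route (a higher number here means more inhibition at the dose given (going by the name of the read-out), a lower number less inhibition), compound 2 stands lowest of the two numbers, with compound 1 nearest, the difference being a number 4.9 percentage points lower from compound 1 to compound 2 (within the scatter). Compound 3 `Cc1ccc(C(=O)/C=C/C2=Cc3ccccc3OC2)cc1` differs from compound 2 by 4-methylphenyl in place of 3-bromophenyl on a carbonyl carbon. Among the measured compounds shown here, no measured step exchanges a halogen-bearing phenyl for a methyl-bearing one, so the single step on record bears only loosely; it shows that moving the bromine on the phenyl left this assay within the scatter. The step to compound 3 is therefore expected to be small, a number 3.7 percentage points lower from compound 2 to compound 3 (within the scatter), with no firm direction. Compound 3 is estimated at 48%, range 30% to 65%.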

Compound 3, a percentage reported as inhibition, in the whole organism at one dose (the size of the read-out at that dose, not a potency): 53.1%
Beside the measured number, compound 3's estimate is 5.1 percentage points below it; the range from low to high includes it.
By their numbers in this assay, from the lowest: compounds 2, 3 and 1 (each within the scatter of the next).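

In this assay, 4-methylphenyl on the carbonyl carbon reads as a number 1.4 percentage points higher from compound 2 to compound 3 (within the scatter) and as a number 3.5 percentage points lower from compound 1 to compound 3 (within the scatter) against the two bromophenyl compounds. The earlier step covered only a shift of the bromine, whereas the series now shows that a methyl-bearing phenyl at this place also stays within the scatter of both. No supporting evidence bears on this result. Still open, on these data alone, is whether an amine or a carboxylic acid on this phenyl would move the read-out beyond the scatter. As far as these compounds go, a longer chain at this place is equally open.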